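This account rests on a few compounds, and the source may have more. Where it says the series, first, only, none or still open, it means among the compounds named here.

Working notes on the series. In an in vitro functional assay on cells for antagonist activity at B1 bradykinin receptor (Homo sapiens), read by luminescence and calcium flux, with a stated time of 2 h (on this read-out higher numbers stand for weaker inhibition and lower numbers for stronger inhibition), compound 3 `Cc1ccc(S(=O)(=O)N2C=CNC(=O)[C@H]2CC(=O)N[C@H]2CCN(C)CC2(C)C)cc1` gives 0.42 nM, the lowest of the three numbers; compound 1 `Cc1ccc(S(=O)(=O)N2C=CNC(=O)[C@H]2CC(=O)NC2CCNc3ccccc32)cc1` gives 21.6 nM and compound 2 `Cc1ccc(S(=O)(=O)N2C=CNC(=O)[C@H]2CC(=O)NC2CCCCC2C)cc1` gives 25.9 nM. The step of a 51-fold lower number from compound 1 to compound 3 (1.71 log units; beyond the scatter) and the step of a 62-fold lower number from compound 2 to compound 3 (1.79 log units; beyond the scatter) are both large, while a 1.2-fold higher number from compound 1 to compound 2 (0.08 log units; within the scatter) is not. Compound 4 `Cc1ccc(S(=O)(=O)N2C=CNC(=O)[C@H]2CC(=O)N[C@H]2CCN(Cc3ccccc3)CC2(C)C)cc1` differs from compound 3 by phenyl in place of hydrogen on a saturated chain carbon bound to an amine nitrogen in a ring, that is, methyl to benzyl. Within the data shown here, every measured step replaced the whole group on the amide-type nitrogen; none touched the substituent on the ring amine nitrogen, so no measured step bears directly on this change. The expectation for compound 4 is therefore a step near or within the scatter, a 1.9-fold higher number from compound 3 to compound 4 (0.28 log units; within the scatter). Compound 4 is estimated at 0.8 nM, between 0.15 nM and 4 nM.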

Compound 4, half-maximal inhibitory concentration: 1.09 nM
Compound 4: the middle estimate sits 1.4-fold (0.13 log units) below what was measured, and the stated range covers the measured number.
By their numbers in this assay, from the lowest: compound 3; then compound 4; then compounds 1 and 2 (each within the scatter of the next).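

Among these compounds, the change from methyl to benzyl gives a 2.6-fold higher number from compound 3 to compound 4 (0.41 log units; beyond the scatter), the first measured step at this position, as all earlier steps replaced the whole group on the amide-type nitrogen. Phenyl in place of hydrogen on a saturated chain carbon bound to an amine nitrogen in a ring therefore costs only a modest loss, with compound 4 still at 1.09 nM. No evidence on hand explains this step.

Open, going by these compounds, is how a longer chain, a carboxylic acid or an amine would fare on this amine nitrogen. On these data alone, whether a substituted phenyl would match phenyl also remains open.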